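The compounds below may be only part of what the source reports. "The series", "measured", "known", "first", "only" and "open" are said of these compounds alone.

Compound 1 `O=C(CCl)Nc1ccc(SCC(=O)Nc2cccc(Cl)c2)cc1` is one of two compounds in this set that the assay could not put a number on. In a functional assay on HeLa cells (Homo sapiens) for antiproliferative activity, read by MTT assay, with a stated time of 48 h (on this read-out higher numbers stand for weaker inhibition and lower numbers for stronger inhibition), compound 1 gives > 80000 nM, which is a limit of the assay rather than a measured value. Compound 2 `O=C(CCl)Nc1ccc(SCC(=O)Nc2ccc(Cl)cc2)cc1` stands in the same place: in this assay compound 2 gives > 80000 nM, again a limit. Among the measured compounds shown here, compound 3 `O=C(CCl)Nc1ccc(SCC(=O)Nc2ccccn2)cc1` is the only member with a number, since in this assay compound 3 gives 7800 nM. The three measured steps all concern the group on the amide-type nitrogen: a step that the two limits leave unreadable from compound 1 to compound 2, an at least 10-fold lower number from compound 1 to compound 3 (1.01 log units; beyond the scatter) and an at least 10-fold lower number from compound 2 to compound 3 (1.01 log units; beyond the scatter); the first of these cannot be sized, given that both of its values sit at the limit of > 80000 nM in this assay, at which 2 of the 3 values shown sit.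

Compound 4 `C=CC(=O)Nc1ccc(SCC(=O)Nc2cccc(Cl)c2)cc1` differs from compound 1 in another part of the molecule: vinyl in place of chloromethyl on a carbonyl carbon. For the measured compounds named here, no measured step touches the carbonyl carbon on the other side of the shared core, so none of them bears on this change, and compound 1 itself offers only a limit as a starting point. Going by the values given here, with no comparable precedent, the step of a number no higher from compound 1 to compound 4 (the limit leaves the size open) is expected to stay within the scatter, and compound 1 being at a limit means the outcome for compound 4 may again be a limit. The estimate for compound 4 is therefore 80000 nM, with a range from 20000 nM to 300000 nM.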

Compound 4, half-maximal inhibitory concentration: > 80000 nM
Compound 4 gave a limit, no number; the forecaster's own chance of this, stated with the estimate: 65%; the middle value lies on the limit itself.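

Compound 1 and compound 4 both sit at a limit of this assay, not at a number, so the step between them cannot be read: the limit of > 80000 nM in this assay, at which 3 of the 4 values shown sit.

The compounds shown leave open whether vinyl in place of chloromethyl on a carbonyl carbon shifts the read-out at all, in either direction.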